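Stereochemical inversion and microsomal stability in the series

A few compounds are considered here, and "the series" means these few. Any claim that something is new, unique, unknown or untested is made for them only; others in the source may bear on it.

Compound 1 `C[C@H](CO)N1C[C@H](C)[C@@H](CN(C)Cc2ccc(Oc3ccccc3)cc2)Oc2c(NC(=O)c3ccncc3)cccc2C1=O` is the reference; in an ADME assay on microsomes (Mus musculus) for metabolic stability, with a stated time of 1 h, tested at 1 uM (on this read-out higher numbers stand for a more stable compound and lower numbers for a less stable compound), compound 1 gives 70%, the only number shown. Compound 2 `C[C@@H]1CN([C@H](C)CO)C(=O)c2cccc(NC(=O)c3ccncc3)c2O[C@@H]1CN(C)Cc1ccc(Oc2ccccc2)cc1` is a stereoisomer of it. In this assay compound 2 gives < 1%, which is a limit of the assay rather than a number. The step of a number at least 69 percentage points lower from compound 1 to compound 2 (beyond the scatter) shows that inversion at the saturated ring carbon alone removes most of the stability, the reading resting on the limit of < 1% in this assay, at which 1 of the 2 values shown sits, and (the fact that compounds 1 and 2 differ only in the configuration as drawn).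

Compound 3 `C[C@@H]1CN([C@@H](C)CO)C(=O)c2cccc(NC(=O)c3ccncc3)c2O[C@@H]1CN(C)Cc1ccc(Oc2ccccc2)cc1` is the target; the change from compound 1 is the two compounds have the same atoms and bonds and differ only in configuration as drawn: 2 of 3 stereo elements differ; a stereocentre at a saturated ring carbon is drawn S in compound 1 and R in compound 3; a stereocentre at a saturated chain carbon is drawn R in compound 1 and S in compound 3. It carries the same ring inversion as compound 2, plus the chain inversion, for which no step is shown. Going by the values given here, the only relevant step is the large loss from compound 1 to compound 2, so a large loss in this assay is expected, a number 65 percentage points lower from compound 1 to compound 3 (beyond the scatter). Compound 3 is therefore expected to give 5% in this assay, with a range from 0% to 30%.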

Compound 3, percent of the compound remaining: < 1%
Compound 3: no number, only a limit; the forecaster's own chance of this, stated with the estimate: 50%; middle value at least 4 percentage points from the limit.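

Compound 3 shows that adding the inversion at the saturated chain carbon to the inversion at the saturated ring carbon does not bring stability back in this assay, with a number at least 69 percentage points lower from compound 1 to compound 3 (beyond the scatter): the fact that compounds 1 and 3 differ only in the configuration as drawn

Compound 3 gives < 1%, which is a limit of the assay and not a number.

The step from compound 2 to compound 3 cannot be read, as both values are limits, so the chain carbon shows no effect of its own while the ring carbon is drawn R: the limit of < 1% in this assay, at which 2 of the 3 values shown sit.

Open is how the chain carbon acts with the ring carbon drawn S, since no compound shown pairs those two configurations. Also open, going by these compounds, is whether an amine or a carboxylic acid in place of the hydroxyl group would change the picture with the ring carbon drawn R.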